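Removing the arylamine substituent on the amidine nitrogen

The source may hold more compounds than are shown below. What is called first, only, known or untested is meant among the compounds shown, and "the series" means these compounds.

Measured compounds:
compound 1, `Cc1ccc(S(=O)(=O)/N=C(/CCNC2=CC(=O)c3ccccc3C2=O)Nc2ccccc2I)cc1`, 24700 nM
compound 2, `Cc1ccc(S(=O)(=O)/N=C(/CCNC2=CC(=O)c3ccccc3C2=O)Nc2cccc(C)c2)cc1`, 18700 nM
compound 3, `Cc1ccc(S(=O)(=O)/N=C(/CCNC2=CC(=O)c3ccccc3C2=O)NC(C)C)cc1`, 44300 nM

In a functional assay on A549 cells (Homo sapiens) for cytotoxicity, read by MTT assay, with a stated time of 48 h (a higher number here means a weaker inhibitor, a lower number a stronger inhibitor), compound 2 gives 18700 nM, the lowest of the three numbers. Its nearest neighbour is compound 1, which gives 24700 nM, with a 1.3-fold lower number from compound 1 to compound 2 (0.12 log units; within the scatter). Compound 3, which gives 44300 nM, stands furthest off, with a 2.4-fold higher number from compound 2 to compound 3 (0.37 log units; beyond the scatter).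

Compound 4, `Cc1ccc(S(=O)(=O)/N=C(\N)CCNC2=CC(=O)c3ccccc3C2=O)cc1`, has not yet been measured. It differs from compound 2 by hydrogen in place of 3-methylphenyl on an amine nitrogen.

Two of the measured steps bear on this change. Replacing the 3-methylphenyl by isopropyl gave a 2.4-fold higher number from compound 2 to compound 3 (0.37 log units; beyond the scatter), and replacing the 2-iodophenyl by isopropyl gave a 1.8-fold higher number from compound 1 to compound 3 (0.25 log units; within the scatter). Both exchanges of an aromatic group for a smaller one left the number the same or higher. For the measured compounds named here, compound 4 goes further, leaving only hydrogen on that nitrogen, which no measured step covers directly, so the expected step is modest and upward, with wide uncertainty.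

Compound 4 is therefore expected to give about 35000 nM, within a range of 15000 nM to 80000 nM, which would be a 1.9-fold higher number from compound 2 to compound 4 (0.27 log units; within the scatter).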

Compound 4, half-maximal inhibitory concentration: 26600 nM
Compound 4: the middle estimate sits 1.3-fold (0.12 log units) above what was measured, and the stated range covers the measured number.
By their numbers in this assay, from the lowest: compounds 2, 1, 4 and 3 (each within the scatter of the next, the first and the last beyond it).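

In this assay the change from (3-methylphenyl)amino to amino, which removes the whole aromatic group of 7 carbon atoms, stays within the scatter (a 1.4-fold higher number from compound 2 to compound 4 (0.15 log units; within the scatter)). The same holds for hydrogen in place of 2-iodophenyl (a 1.1-fold higher number from compound 1 to compound 4 (0.03 log units; within the scatter)) and for hydrogen in place of isopropyl (a 1.7-fold lower number from compound 3 to compound 4 (0.22 log units; within the scatter)), so compound 4 cannot be told apart from any of the three substituted compounds, even though compound 2 and compound 3 lie beyond the scatter of each other. Among these compounds, therefore, a group on this amine nitrogen is not required for a number of this size, and the gap between compound 2 and compound 3 does not extend into a trend that continues down to hydrogen.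

Nothing given here accounts for these numbers. From the compounds shown here alone, it remains open whether a longer chain, a benzyl group or a carboxylic acid on this nitrogen would move the number beyond the scatter of compound 4, or whether all such groups would stay in the same narrow band.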